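A few compounds are considered here, and "the series" means these few. Any claim that something is new, unique, unknown or untested is made for them only; others in the source may bear on it.

Three compounds have been measured in a functional assay on NCI-H522 cells (Homo sapiens) for cytotoxicity, read by sulforhodamine B assay, with a stated time of 48 h; on this read-out lower numbers stand for stronger inhibition of growth and higher numbers for weaker inhibition of growth:

Compound 1, `ClCc1ccccc1Cn1cnc2c(Cl)nc(Cl)nc21`, gives 1990 nM.
Compound 2, `ClCc1cccc(Cn2cnc3c(Cl)nc(Cl)nc32)c1`, gives 5370 nM.
Compound 3, `Nc1nc(Cl)c2ncn(Cc3ccccc3CCl)c2n1`, gives 9330 nM.

Compound 1 and compound 2 have the same atoms joined differently; the difference between the two cores is not broken down here. Compound 3 arises from compound 1 by a single change, (amino in place of chloro on an aromatic carbon), and this change produced a 4.7-fold higher number from compound 1 to compound 3 (0.67 log units; beyond the scatter). Compound 2 sits with compound 3 within the usual scatter, so no order between those two can be stated.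

Compound 4, `Nc1nc(Cl)c2ncn(Cc3cccc(CCl)c3)c2n1`, has not yet been measured in this assay. It arises from compound 2 by amino in place of chloro on an aromatic carbon, and the surroundings of the place are the same as for the change from compound 1 to compound 3, so it is the same change on a differently joined core. Compound 4 is therefore expected to show a step of about a 4.3-fold higher number from compound 2 to compound 4 (0.63 log units; beyond the scatter), resting on the single earlier occurrence, a 4.7-fold higher number from compound 1 to compound 3 (0.67 log units; beyond the scatter), applied to compound 2 at 5370 nM. Compound 4 is accordingly estimated at 23000 nM, with a range from 9000 nM to 60000 nM expected.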

Compound 4, concentration for total growth inhibition: 13500 nM
Estimate against measurement, compound 4: 1.7-fold (0.23 log units) above, within the range that was stated.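

In this assay, amino in place of chloro on an aromatic carbon gave a 2.5-fold higher number from compound 2 to compound 4 (0.40 log units; beyond the scatter), the same direction as on the core of compound 1. The two steps cannot be told apart in size: the same change on two cores in this assay, a 4.7-fold higher number (0.67 log units; beyond the scatter) from compound 1 to compound 3 and a 2.5-fold higher number (0.40 log units; beyond the scatter) from compound 2 to compound 4, 1.9-fold (0.27 log units) apart, within the scatter of two such steps

In this small series, then, the change carried over between the two differently joined cores, moving the number the same way each time. Among these compounds, with only two pairs, however, this does not show that the size of the step depends on the core, nor that the change would behave alike on any further core, and it gives no explanation for the rise.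

The compounds shown leave open whether a methylamino group, a dimethylamino group or a methoxy group at the same place would follow amino or behave differently. From the compounds shown here alone, it is also open how the step would look on either core if a hydroxymethyl group or a longer chain bearing chloro stood in place of the chloromethyl group.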